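The compounds below may be only part of what the source reports. "The series", "measured", "known", "first", "only" and "open" are said of these compounds alone.

In a functional assay on A549 cells (Homo sapiens) for cytotoxicity, read by MTT assay, with a stated time of 24 h, tested at 20 uM (on this read-out higher numbers stand for a weaker effect at the one concentration tested and lower numbers for a stronger effect), compound 3 `CCCCCCCCCCCCCCCCOC(=O)CCC(=O)N1CCN(CCCOc2cc3c(Nc4ccc(F)c(Cl)c4)ncnc3cc2OC)CC1` gives 91.7%. Its two neighbours are compound 1 `CCCCCCCCCCCCCOC(=O)CCC(=O)N1CCN(CCCOc2cc3c(Nc4ccc(F)c(Cl)c4)ncnc3cc2OC)CC1`, which gives 93.8%, and compound 2 `CCCCCCCCCCCCCCCOC(=O)CCC(=O)N1CCN(CCCOc2cc3c(Nc4ccc(F)c(Cl)c4)ncnc3cc2OC)CC1`, which gives 91.2%, so compound 3 sits among three numbers that all lie within the usual scatter of one another. Compound 4 `CCCCCCCCCCCCCCCCCOC(=O)CCC(=O)N1CCN(CCCOc2cc3c(Nc4ccc(F)c(Cl)c4)ncnc3cc2OC)CC1` has not yet been measured. It differs from compound 3 by methyl in place of hydrogen on a saturated chain carbon, ten or more bonds along the chain from an oxygen next to a carbonyl group. The same kind of change has already been seen: a number 0.5 percentage points higher from compound 2 to compound 3 (within the scatter), and the longer extensions a number 2.6 percentage points lower from compound 1 to compound 2 (within the scatter) and a number 2.1 percentage points lower from compound 1 to compound 3 (within the scatter). On that basis, a step of a number 0.3 percentage points higher from compound 3 to compound 4 (within the scatter) is expected, nothing beyond the scatter. Compound 4 is therefore estimated at 92%, with a range from 85% to 98%.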

Compound 4, a percentage reported as activity, at one concentration (the size of the read-out at that concentration, not a potency): 97.2%
Estimate against measurement, compound 4: 5.2 percentage points below; the measured number falls inside the stated range.
By their numbers in this assay, from the lowest: compounds 2, 3, 1 and 4 (each within the scatter of the next).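

Methyl in place of hydrogen at this far end of the chain gives a step (a number 5.5 percentage points higher from compound 3 to compound 4 (within the scatter)) that stays within the scatter, and so do the longer extensions (a number 6 percentage points higher from compound 2 to compound 4 (within the scatter); a number 3.4 percentage points higher from compound 1 to compound 4 (within the scatter)). Across these four chain lengths, then, no compound stands apart from the others in this assay. No available evidence accounts for where these numbers fall. Still open, on these data alone, is whether a much shorter or much longer chain, or a chain ending in an amine or a carboxylic acid, would give a step beyond the scatter.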